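Swapping the cyclohexylmethyl for a methoxyphenoxy group

The compounds below may be only part of what the source reports. "The series", "measured", "known", "first", "only" and "open" are said of these compounds alone.

Compound 3 `c1coc(CNCCCNc2ccnc3cc(CC4CCCCC4)ccc23)c1` gives 1700 nM in an ADME assay on HepG2 cells (Homo sapiens) for cytotoxicity, read by luminescence, CellTiter-Glo and ATP content, with a stated time of 72 h (on this read-out lower numbers stand for an effect already at smaller amounts and higher numbers for an effect only at larger amounts of compound), the lowest of the three numbers shown. Compound 2 `CC(C)(C)c1ccc(-c2ccc3c(NCCCNCc4ccco4)ccnc3c2)cc1` gives 3150 nM, and the difference a 1.9-fold lower number from compound 2 to compound 3 (0.27 log units; within the scatter) does not separate the two. Compound 1 `CN(C)c1cccc(Oc2ccc3c(NCCCNCc4ccco4)ccnc3c2)c1` gives 16000 nM, and the step of a 9.4-fold lower number from compound 1 to compound 3 (0.97 log units; beyond the scatter) is the clearest among the measured pairs. Compound 4 `COc1ccc(Oc2ccc3c(NCCCNCc4ccco4)ccnc3c2)cc1` carries the change (4-methoxyphenoxy in place of cyclohexylmethyl on an aromatic carbon). Compound 1 also carries a phenoxy group on that carbon, so the step from compound 1 to compound 3 bears most directly on this change, and reversing it points toward a higher number. The change is therefore expected to raise the number, by a step estimated as a 5.9-fold higher number from compound 3 to compound 4 (0.77 log units; beyond the scatter). The value expected for compound 4 is 10000 nM, with a likely range from 4000 nM to 30000 nM.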

Compound 4, half-maximal effective concentration: 5300 nM
For compound 4 the middle estimate is 1.9-fold (0.28 log units) above the measured one; the range from low to high includes it.
By their numbers in this assay, from the lowest: compounds 3, 2 and 4 (each within the scatter of the next, the first and the last beyond it); then compound 1.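

A second oxygen-linked group on this aromatic carbon also reads higher than cyclohexylmethyl (a 3.1-fold higher number from compound 3 to compound 4 (0.49 log units; beyond the scatter)), as the 3-(dimethylamino)phenoxy group did. The two phenoxy groups also stand apart (a 3.0-fold lower number from compound 1 to compound 4 (0.48 log units; beyond the scatter)), so what the outer ring carries matters here, not the oxygen link alone. Against the directly attached 4-(tert-butyl)phenyl, the change does not separate the compounds (a 1.7-fold higher number from compound 2 to compound 4 (0.23 log units; within the scatter)), so compound 2 goes against any simple split by linker. From the compounds shown here alone, how a plain phenoxy group or a phenoxy ring bearing a carboxylic acid would read stays open. No measurement here explains these differences.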